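Sulfonamide aryl variation in a pyrimidinylaminomethyl benzamide series

The source may report more compounds than this note shows. Statements on the series, on what has been measured and on what is new or still open speak of the compounds shown alone.

Measured compounds:
compound 1 `O=C(NCc1ccc(CNS(=O)(=O)c2cccc(C(F)(F)F)c2)cc1)c1ccc(CNc2ncccn2)cc1`, 1000 nM
compound 2 `O=C(NCc1ccc(CNS(=O)(=O)c2ccccc2Cl)cc1)c1ccc(CNc2ncccn2)cc1`, 1000 nM
compound 3 `O=C(NCc1ccc(CNS(=O)(=O)c2ccc3c(c2)CCO3)cc1)c1ccc(CNc2ncccn2)cc1`, 1000 nM

Three compounds share one core and differ only in the aryl group on the sulfonyl sulfur. In an assay on MDA-MB-231 cells for binding affinity to C-X-C chemokine receptor type 4 (Homo sapiens), read by microscopy, with stated times of 10 min and 30 min (a higher number here means that more compound is needed for the effect, a lower number that less compound is needed), compound 1 gives 1000 nM, compound 2 gives 1000 nM and compound 3 gives 1000 nM. Compound 2 stands level with both others: no change at the digits printed from compound 1 to compound 2 (within the scatter), no change at the digits printed from compound 2 to compound 3 (within the scatter), and no change at the digits printed from compound 1 to compound 3 (within the scatter). Across the three aryl groups tried so far the read-out in this assay does not move.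

Compound 4 `O=C(NCc1ccc(CNS(=O)(=O)c2ccccc2F)cc1)c1ccc(CNc2ncccn2)cc1` is the next member. Its change from compound 2 is fluoro in place of chloro on an aromatic carbon, read one bond further out as (2-chlorophenyl)sulfonyl to (2-fluorophenyl)sulfonyl. For the measured compounds named here, no measured step swaps one halogen for another on that ring; the steps that bear on it are the three aryl replacements above, each within the scatter, and a single halogen swap is a smaller change than any of them. The step from compound 2 to compound 4 in this assay is therefore expected to be no change at the digits printed from compound 2 to compound 4 (within the scatter), no movement beyond the scatter. Compound 4 is estimated at 1000 nM, with a range of 500 nM to 2000 nM.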

Compound 4, effective concentration (reported as EC, without a stated level of effect): 1000 nM
Beside the measured number, compound 4's estimate shows no gap at the digits printed, and the stated range covers the measured number.
By their numbers in this assay, from the lowest: compounds 1, 2, 3 and 4 (each within the scatter of the next).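

In this assay, the series now includes a direct halogen swap on an aromatic carbon ortho to a large group, and fluoro in place of chloro does not move the read-out (no change at the digits printed from compound 2 to compound 4 (within the scatter)). The 2-fluorophenyl group also stands level with the two other aryl groups on the sulfonyl sulfur (no change at the digits printed from compound 3 to compound 4 (within the scatter); no change at the digits printed from compound 1 to compound 4 (within the scatter)), so all four aryl groups shown give the same printed read-out. No measurement shown offers an explanation for this flat result.

All four compounds carry an aryl group on the sulfonyl sulfur, leaving open whether an amine or a carboxylic acid on that ring, or a longer alkyl chain in its place, would shift the read-out. Going by these compounds, the shared core stays constant in all four, so the effect of any change there also remains open.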